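The source may hold more compounds than are shown below. What is called first, only, known or untested is meant among the compounds shown, and "the series" means these compounds.

Measured compounds in an assay on isolated protein for inhibition of serine/threonine-protein kinase Chk2 (Homo sapiens), read by mobility shift assay, tested at 30 uM; a lower number here means less inhibition, a higher number more inhibition at the concentration tested (going by the name of the read-out):

- compound 1 `Cc1cc2c(c(N)nn2C)c(=O)[nH]1` gives 3%
- compound 2 `Cn1nc(N)c2c(=O)[nH]c(-c3ccccc3)cc21` gives 16%

Within the data shown here, compound 2 stands highest of the two numbers measured so far; the only other value is that of compound 1, and the one step between them, a number 13 percentage points higher from compound 1 to compound 2 (beyond the scatter), came with a phenyl in place of methyl on an aromatic carbon. Compound 3 `CC(=O)Nc1nn(C)c2cc(-c3ccccc3)[nH]c(=O)c12` keeps the phenyl of compound 2 and changes a different part of the molecule: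

acetyl in place of hydrogen on a nitrogen on an aromatic ring

Among the measured compounds shown here, no measured step concerns this nitrogen, so the phenyl step gives no guide to the size or direction of the change from compound 2 to compound 3; the two structures differ only in the acetyl group, and nothing measured here speaks to it. With no evidence either way, the expected step is a number 2 percentage points lower from compound 2 to compound 3 (within the scatter), that is, no change beyond the scatter. Compound 3 is therefore estimated at 14%, with a likely range from 0% to 32%.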

Compound 3, a percentage reported as inhibition, at one concentration (the size of the read-out at that concentration, not a potency): 4%
The estimate for compound 3 lay 10 percentage points above the measured number; the measured number falls inside the stated range.
By their numbers in this assay, from the lowest: compounds 1 and 3 (each within the scatter of the next); then compound 2.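

Changing amino to acetamido, with acetyl in place of hydrogen on the nitrogen, gives a number 12 percentage points lower from compound 2 to compound 3 (beyond the scatter) in this assay, a modest step. The earlier pair showed a change only at the aromatic carbon that carries the phenyl; this step shows that the nitrogen also responds to what is placed on it, even with the phenyl kept. Nothing measured here bears on why the number falls with the acetyl group.

As far as these compounds go, it remains open whether any group on this nitrogen would give a similar step, or whether it is specific to acetyl; a methyl group or a longer acyl chain such as butanoyl would help separate the two. Also open, from the compounds shown here alone, is whether acetyl would act in the same way on compound 1, which carries methyl where compound 2 carries phenyl.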